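A few compounds are considered here, and "the series" means these few. Any claim that something is new, unique, unknown or untested is made for them only; others in the source may bear on it.

Measured so far in a functional assay on 5637 cells (Homo sapiens) for antiproliferative activity, read by crystal violet staining, with a stated time of 96 h; on this read-out higher numbers stand for weaker inhibition and lower numbers for stronger inhibition:
Compound 1 `C[C@@H]1O[C@@H](N2C(=O)/C(=C3\Nc4ccccc4C3=O)c3ccccc32)[C@H](O)[C@H](O)[C@H]1O` gives > 25000 nM, which is a limit of the assay rather than a number.
Compound 2 `C[C@@H]1O[C@H](N2C(=O)/C(=C3\Nc4ccccc4\C3=N/O)c3ccccc32)[C@H](O)[C@H](O)[C@H]1O` gives 15500 nM.
Compound 3 `C[C@@H]1O[C@H](N2C(=O)/C(=C3\Nc4ccc(Cl)cc4C3=O)c3ccccc32)[C@H](O)[C@H](O)[C@H]1O` gives 8230 nM.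

Compound 3 has the lowest of the two numbers shown, but its nearest neighbour, compound 2, lies within the scatter of it, so no order between the two can be claimed. Compound 4 `C[C@@H]1O[C@H](N2C(=O)/C(=C3\Nc4ccccc4C3=O)c3ccccc32)[C@H](O)[C@H](O)[C@H]1O` differs from compound 3 by hydrogen in place of chloro on an aromatic carbon. Within the data shown here, no measured pair shows this change, so the size of the step is uncertain; the expectation is a modest rise in this assay, toward weaker inhibition, giving an expected step of a 1.8-fold higher number from compound 3 to compound 4 (0.26 log units; within the scatter). Compound 4 is estimated at 15000 nM, with a range from 6000 nM to 40000 nM.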

Compound 4, half-maximal inhibitory concentration: > 12500 nM
Compound 4 gave a limit, no number (the forecaster's own chance of this, stated with the estimate: 30%); the middle value lies beyond the limit too.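

In this assay, among these compounds, the first measured swap at this aromatic carbon, hydrogen in place of chloro, gives an at least 1.5-fold higher number from compound 3 to compound 4 (0.18 log units; that floor lies within the scatter) and so points toward weaker inhibition without the floor clearing the scatter. Compound 4 stands at a limit of the assay, not a number: the limit of > 12500 nM in this assay, at which 1 of the 4 values shown sits.

Going by these compounds, the step from compound 1 to compound 4 cannot be read, so the effect of the one changed stereocentre stays open: the fact that compounds 1 and 4 differ only in the configuration as drawn. Also open, on these data alone, is how bromo or a methoxy group would compare with chloro at this carbon.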